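Shortening the ketone chain: isobutyl to isopropyl

The source may hold more compounds than are shown below. What is called first, only, known or untested is meant among the compounds shown, and "the series" means these compounds.

Compound 1 `Cc1cc(C(=O)O)ccc1OCCCCOc1ccc(C(=O)CC(C)C)c(O)c1C` gives 192 nM in an assay on HEK293 cells for positive allosteric modulation of metabotropic glutamate receptor 2 (Rattus norvegicus), read by thallium flux, with a stated time of 2.5 min (a higher number here means that more compound is needed for the effect, a lower number that less compound is needed), the second highest of the three numbers measured. Compound 2 `Cc1c(OCCCCOc2ccc(C(=O)O)cc2F)ccc(C(=O)CC(C)C)c1O` gives 102 nM, and compound 3 `Cc1ccc(C(=O)O)cc1OCCCCOc1ccc(C(=O)CC(C)C)c(O)c1C` gives 454 nM; the measured steps, a 1.9-fold lower number from compound 1 to compound 2 (0.27 log units; within the scatter) and a 2.4-fold higher number from compound 1 to compound 3 (0.37 log units; beyond the scatter), both concern the carboxy-bearing aromatic ring. Compound 4 `Cc1cc(C(=O)O)ccc1OCCCCOc1ccc(C(=O)C(C)C)c(O)c1C` differs from compound 1 elsewhere: isopropyl in place of isobutyl on a carbonyl carbon. For the measured compounds named here, no measured step touches this ketone side chain, so the data give no direction for it. With no such comparison available, compound 4 is expected to sit within the scatter of compound 1, an expected step of a 1.0-fold higher number from compound 1 to compound 4 (0.02 log units; within the scatter) in this assay. The estimate for compound 4 is 200 nM, with a range from 70 nM to 600 nM.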

Compound 4, half-maximal effective concentration: 234 nM
Estimate against measurement, compound 4: 1.2-fold (0.07 log units) below; low and high end bracket the measured number.
By their numbers in this assay, from the lowest: compounds 2, 1, 4 and 3 (each within the scatter of the next, the first and the last beyond it).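

The ketone side chain, the same in the three earlier compounds, now has its first reading: isopropyl in place of isobutyl on the carbonyl carbon gives a 1.2-fold higher number from compound 1 to compound 4 (0.09 log units; within the scatter) in this assay. In this single pair, then, the shorter branched chain leaves the number within the scatter. No evidence bears on this result.

Going by these compounds, whether a longer chain, a cyclopropyl group or an amine on the carbonyl carbon would do the same remains open. So does whether isopropyl would behave alike with the aromatic rings of compound 2 and compound 3.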